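The source may report more compounds than this note shows. Statements on the series, on what has been measured and on what is new or still open speak of the compounds shown alone.

Measured compounds:
Compound 1 `COc1cc(-c2cc(/C=C/C(=O)c3ccc(N)cc3)[nH]n2)cc(OC)c1OC` — 2000 nM
Compound 2 `COc1ccc(C(=O)/C=C/c2cc(-c3cc(OC)c(OC)c(OC)c3)n[nH]2)cc1OC` — 620 nM
Compound 3 `COc1cc(-c2cc(/C=C/C(=O)c3ccccc3)[nH]n2)cc(OC)c1OC` — 2300 nM

In a functional assay on MDA-MB-231 cells (Homo sapiens) for inhibition, read by MTT assay, with a stated time of 48 h (a lower number here means a stronger inhibitor, a higher number a weaker inhibitor), compound 3 gives the highest of the three numbers: compound 1 sits within the scatter of it, while compound 2 lies further off, with a 3.7-fold higher number from compound 2 to compound 3 (0.57 log units; beyond the scatter). Compound 4 `COc1cc(-c2cc(/C=C/C(=O)c3ccc(F)c(F)c3)[nH]n2)cc(OC)c1OC` differs from compound 3 by one change, (3,4-difluorophenyl in place of phenyl on a carbonyl carbon). For the measured compounds named here, two measured steps bear on this position: a 3.7-fold higher number from compound 2 to compound 3 (0.57 log units; beyond the scatter), a modest change when two substituents were removed from this ring, and a 1.2-fold higher number from compound 1 to compound 3 (0.06 log units; within the scatter), which stayed within the scatter. Going by the values given here, no fluorinated analogue has been measured here, so the expectation rests on those two steps alone. Compound 4 is therefore expected to give 1800 nM, between 700 nM and 4500 nM, meaning a 1.3-fold lower number from compound 3 to compound 4 (0.11 log units; within the scatter).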

Compound 4, half-maximal inhibitory concentration: 1500 nM
Compound 4: middle estimate off by 1.2-fold (0.08 log units), on the high side, and the stated range covers the measured number.
By their numbers in this assay, from the lowest: compound 2; then compounds 4, 1 and 3 (each within the scatter of the next).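

In this assay, 3,4-difluorophenyl on the carbonyl carbon stays within the scatter of phenyl (a 1.5-fold lower number from compound 3 to compound 4 (0.19 log units; within the scatter)) and of 4-aminophenyl (a 1.3-fold lower number from compound 1 to compound 4 (0.12 log units; within the scatter)). Only 3,4-dimethoxyphenyl stands apart (a 2.4-fold higher number from compound 2 to compound 4 (0.38 log units; beyond the scatter)), so placing two substituents on this ring does not by itself separate a compound from the phenyl parent, and among the four groups compound 2 alone is set off from the rest. Nothing measured here offers an explanation for this difference. Open, from the compounds shown here alone, is whether 4-methoxyphenyl, with one methoxy group, or 3,4-dichlorophenyl would stay with compound 3 or move towards compound 2.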